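Tert-butyl to trifluoromethoxy on a fused aromatic carbon

The compounds below may be only part of what the source reports. "The series", "measured", "known", "first", "only" and "open" are said of these compounds alone.

Compound 1 `C=C(C)c1ccc2c(c1)c(=O)c(C(=O)Nc1ccc(Oc3ncnc4[nH]cc(-c5ccccc5)c34)c(F)c1)c(C)n2C`: 170 nM
Compound 2 `Cc1c(C(=O)Nc2ccc(Oc3ncnc4[nH]cc(-c5ccccc5)c34)c(F)c2)c(=O)c2cc(C(C)(C)C)ccc2n1C`: 42 nM

Of the compounds shown here, two have been measured in an assay on isolated protein for inhibition of tyrosine-protein kinase receptor UFO (Homo sapiens), read by FRET and Z'-LYTE, with a stated time of 1.5 h; on this read-out higher numbers stand for weaker inhibition and lower numbers for stronger inhibition. Compound 2 stands with the lowest number of the two; its nearest neighbour is compound 1, and the measured step of a 4.0-fold lower number from compound 1 to compound 2 (0.61 log units; beyond the scatter) sets the two apart. Compound 3 `Cc1c(C(=O)Nc2ccc(Oc3ncnc4[nH]cc(-c5ccccc5)c34)c(F)c2)c(=O)c2cc(OC(F)(F)F)ccc2n1C` has not yet been measured; it differs from compound 2 by trifluoromethoxy in place of tert-butyl on an aromatic carbon.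

Going by the values given here, no measured step exchanges tert-butyl for trifluoromethoxy, so the only guide is the step from compound 1 to compound 2, which shows that a change at this aromatic carbon can move the number by a modest amount. The direction for a trifluoromethoxy group cannot be read from that step. For compound 3 the expected outcome in this assay is therefore a number close to that of compound 2, a step of a 1.9-fold higher number from compound 2 to compound 3 (0.28 log units; within the scatter) of a size that may or may not exceed the scatter. The estimate for compound 3 is 80 nM, with a range from 25 nM to 250 nM.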

Compound 3, half-maximal inhibitory concentration: 74 nM
Estimate against measurement, compound 3: 1.1-fold (0.03 log units) above; the measured number falls inside the stated range.
By their numbers in this assay, from the lowest: compounds 2 and 3 (each within the scatter of the next); then compound 1.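

In this assay, the aromatic carbon meta and para to a fused ring accepts trifluoromethoxy as readily as tert-butyl: the step of a 1.8-fold higher number from compound 2 to compound 3 (0.25 log units; within the scatter) cannot be distinguished from repeat-measurement noise, even though the two groups differ in their atoms and in the hydrogen-bond acceptor counted for trifluoromethoxy. Trifluoromethoxy also gives a 2.3-fold lower number from compound 1 to compound 3 (0.36 log units; beyond the scatter) and so, like tert-butyl in the step of a 4.0-fold lower number from compound 1 to compound 2 (0.61 log units; beyond the scatter), stands apart from 1-methylethenyl. Nothing available explains these numbers.

The compounds shown leave open whether an amine, a carboxylic acid or a methoxy group on this carbon would keep the number near those of compound 2 and compound 3. They also leave open whether these steps would hold with a different group elsewhere on the shared core.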